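Swapping methyl for ethoxy on a carbonyl carbon

The compounds below may be only part of what the source reports. "The series", "measured", "known", "first", "only" and "open" are said of these compounds alone.

Compound 1 `CC(=O)N(C)C(C)C#CCn1ccnc1`: 3 mg/kg
Compound 2 `CC(=O)N(C)CC#CCn1ccnc1`: 1.4 mg/kg
Compound 3 `CC(=O)N(C)CC#CCn1cncc1C`: 45 mg/kg

In a functional assay on the whole organism for agonist activity, with Mus musculus as the target (on this read-out higher numbers stand for an effect only at larger amounts of compound and lower numbers for an effect already at smaller amounts), compound 2 gives 1.4 mg/kg, the lowest of the three numbers, so it acts at the smallest dose measured so far. Compound 4 `CCOC(=O)N(C)CC#CCn1ccnc1` keeps the rest of compound 2 but has ethoxy in place of methyl on a carbonyl carbon.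

Going by the values given here, no measured step touches this carbonyl carbon, so the other two steps offer only a rough guide. Hydrogen in place of methyl on a saturated chain carbon gave a modest step, a 2.1-fold lower number from compound 1 to compound 2 (0.33 log units; beyond the scatter). Methyl in place of hydrogen on an aromatic carbon gave a large one, a 32-fold higher number from compound 2 to compound 3 (1.51 log units; beyond the scatter). Among these three compounds, the added methyl goes with a higher number in both cases, though by very different amounts. A moderate rise in this assay therefore seems likely, but this is uncertain. The expected step is a 4.3-fold higher number from compound 2 to compound 4 (0.63 log units; beyond the scatter). The estimate for compound 4 is 6 mg/kg, with an expected range of 1.2 mg/kg to 30 mg/kg.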

Compound 4, dose for half-maximal effect: > 100 mg/kg
Compound 4 was reported as a limit (the forecaster's own chance of this, stated with the estimate: 10%); at least 16-fold (1.22 log units) between middle value and limit.
By their numbers in this assay, from the lowest: compound 2; then compound 1; then compound 3. At a limit, above all of these: compound 4.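

The carbonyl carbon turns out to be a sensitive place in the molecule: in this assay, changing acetyl to ethoxycarbonyl, with the rest of the structure kept, gives an at least 71-fold higher number from compound 2 to compound 4 (1.85 log units; beyond the scatter). A change at this place can therefore cost as much as the methyl on the aromatic carbon, which gave a 32-fold higher number from compound 2 to compound 3 (1.51 log units; beyond the scatter). Compound 4 gives only a limit of the assay, so the true size of its step stays unknown: the limit of > 100 mg/kg in this assay, at which 1 of the 4 values shown sits.

Only acetyl and ethoxycarbonyl appear at this carbonyl carbon, so the compounds shown cannot tell whether the added oxygen or the longer chain goes with the higher number. A propionyl group, which lengthens the chain without that oxygen, and a methoxycarbonyl group, which keeps the oxygen on a shorter chain, would help to separate the two.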